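Swapping Chlorine for Fluorine on the Outer Ring

This account rests on a few compounds, and the source may have more. Where it says the series, first, only, none or still open, it means among the compounds named here.

- compound 1 `COc1cccc(C=C2C(=O)N(c3ccc(Cl)cc3)N(c3ccc(Cl)cc3)C2=O)c1OC`: 6800 nM
- compound 2 `O=C1C(=Cc2ccc(Cl)cc2Cl)C(=O)N(c2ccc(Cl)cc2)N1c1ccc(Cl)cc1`: 60200 nM

Both values come from a functional assay on ECa-109 cells (Homo sapiens) for cytotoxicity, read by MTT assay, with a stated time of 72 h; on this read-out lower numbers stand for stronger inhibition and higher numbers for weaker inhibition. Of the two, compound 2 gives the higher number, 60200 nM, and so the weaker inhibition. Compound 3 `O=C1C(=Cc2ccc(F)cc2F)C(=O)N(c2ccc(Cl)cc2)N1c1ccc(Cl)cc1` has not been measured and differs from compound 2 in one group: 2,4-difluorophenyl in place of 2,4-dichlorophenyl on a double-bonded chain carbon bound to a double-bonded ring carbon.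

Among the measured compounds shown here, only one measured step bears on this place, an 8.9-fold higher number from compound 1 to compound 2 (0.95 log units; beyond the scatter), and it lies beyond the usual scatter. In that step 2,4-dichlorophenyl replaced 2,3-dimethoxyphenyl, whereas here only chlorine gives way to fluorine, so a smaller step is expected in this assay. Two compounds cannot settle the direction, but with compound 2 at 60200 nM, a slight move to a lower number is expected. The estimate amounts to a 1.7-fold lower number from compound 2 to compound 3 (0.24 log units; within the scatter). For compound 3 the estimated value is 35000 nM, with an expected range of 11000 nM to 100000 nM.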

Compound 3, half-maximal inhibitory concentration: 13100 nM
Estimate against measurement, compound 3: 2.7-fold (0.43 log units) above; measured number inside the range.
By their numbers in this assay, from the lowest: compounds 1 and 3 (each within the scatter of the next); then compound 2.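

In this assay, the identity of the halogen on this outer ring matters: 2,4-difluorophenyl in place of 2,4-dichlorophenyl gives a 4.6-fold lower number from compound 2 to compound 3 (0.66 log units; beyond the scatter), a step beyond the scatter even though the ring itself stays the same. 2,4-difluorophenyl in place of 2,3-dimethoxyphenyl gives a 1.9-fold higher number from compound 1 to compound 3 (0.28 log units; within the scatter), so compound 1 and compound 3 cannot be told apart, and the weak result of compound 2 does not hold for both halogenated rings at this place. Nothing measured here explains the difference between chlorine and fluorine.

On these data alone, it remains open whether a phenyl ring with a single fluorine would fall nearer compound 2 or compound 3, and how a ring carrying an amine or a carboxylic acid would behave. As far as these compounds go, whether the fluorine step holds with other changes to the shared core also remains unknown.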